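The source may report more compounds than this note shows. Statements on the series, on what has been measured and on what is new or still open speak of the compounds shown alone.

Measured compounds and their values in an ADME assay (a lower number here means that the compound disappears faster, a higher number that the compound lasts longer), are as follows.

Compound 1 `COc1ccc(C[S+]([O-])c2ncccc2C(=O)Nc2ccncc2)c(OC)c1C` gives 11.6 h
Compound 2 `COc1cc(OC)c(C[S+]([O-])c2ncccc2C(=O)Nc2ccncc2)cc1Br` gives 28.8 h
Compound 3 `COc1ccc(C[S+]([O-])c2ncccc2C(=O)Nc2ccncc2)c(OC)c1` gives 0.84 h

Compound 3 has the lowest number of the three in this assay and lies well beyond the scatter from both of the others. Compound 4 `COc1cc(C)c(C[S+]([O-])c2ncccc2C(=O)Nc2ccncc2)c(OC)c1` has not yet been measured. It differs from compound 3 by methyl in place of hydrogen on an aromatic carbon and in nothing else.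

Within the data shown here, two measured steps bear on this change. The first is a 14-fold lower number from compound 1 to compound 3 (1.14 log units; beyond the scatter) with hydrogen in place of methyl on an aromatic carbon. The second is a 34-fold lower number from compound 2 to compound 3 (1.54 log units; beyond the scatter) with hydrogen in place of bromo on an aromatic carbon. Both are large, and both show compound 3 with the lower number. The step from compound 1 is the closer guide, since it also concerns a methyl. Neither step, however, involves the aromatic carbon that carries the new methyl in compound 4, so they speak more to direction than to size.

A higher number is therefore expected in this assay, by a step beyond the scatter but probably smaller than the measured ones. The expected change is a 6.0-fold higher number from compound 3 to compound 4 (0.77 log units; beyond the scatter) and remains an estimate. For compound 4 the estimated half-life is 5 h with an expected range from 1.5 h to 20 h as its span.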

Compound 4, half-life: 0.09 h
Compound 4: the middle estimate sits 56-fold (1.74 log units) above what was measured; the whole stated range lies above it.
By their numbers in this assay, from the lowest: compound 4; then compound 3; then compound 1; then compound 2.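

In this assay, methyl in place of hydrogen on the aromatic carbon that is ortho to a large group and meta to two methoxy groups gives a 9.3-fold lower number from compound 3 to compound 4 (0.97 log units; beyond the scatter) and so shortens the half-life, a direction that the earlier steps had not shown for any group. The earlier methyl step runs the other way, since a 14-fold lower number from compound 1 to compound 3 (1.14 log units; beyond the scatter) comes with the loss of a methyl from a different aromatic carbon, so among these compounds the same small group raises or lowers the number according to the carbon that carries it, and a methyl at one carbon of this ring says little about a methyl at another. Nothing measured here accounts for this reversal of direction.

The compounds shown leave open whether a fluorine atom, a hydroxyl group or an ethyl group on this same aromatic carbon would also lower the number, and by how much compared with methyl. They also leave open whether this methyl would lower the number to a similar degree with the bromo of compound 2 or the methyl of compound 1 on the same ring.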